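The source may report more compounds than this note shows. Statements on the series, on what has been measured and on what is new or still open speak of the compounds shown alone.

Compound 1 `C=C1C(=O)[C@]23C[C@@]1(O)CC[C@H]2c1ccc(OS(=O)(=O)c2ccc(C)cc2)c(C)c1[C@@H]3Cn1cc(-c2ccc(Br)cc2)nn1` gives 1020 nM in a functional assay on HL-60 cells (Homo sapiens) for cytotoxicity, read by MTT assay, with a stated time of 4 days; a higher number here means a weaker inhibitor, a lower number a stronger inhibitor.
Compound 2 `C=C1C[C@]23C[C@@]1(O)CC[C@H]2c1ccc(O)c(C)c1[C@@H]3Cn1cc(-c2ccc(C(F)(F)F)cc2)nn1` gives 8950 nM in this assay.

Within the data shown here, of the two numbers measured so far, compound 2 stands highest; its nearest neighbour is compound 1, whose number is lower by a margin beyond the scatter. Among the measured compounds shown here, the two compounds differ in more than one place, so their values show only that compound 2 is the weaker of the pair in this assay.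

Compound 3 `C=C1C[C@]23C[C@@]1(O)CC[C@H]2c1ccc(O)c(C)c1[C@@H]3Cn1cc(-c2ccc(F)cc2)nn1` keeps the core of compound 2 and changes only the substituent on the phenyl ring that hangs from the triazole: fluoro in place of trifluoromethyl on an aromatic carbon. For the measured compounds named here, no measured pair with this exact change exists among the compounds at hand, so the size of the step can only be guessed. The change is small in what it removes and adds, and nothing in the measured data points one way or the other, so a step within the scatter, in either direction, is the expectation in this assay. The step this expectation implies is a 1.1-fold higher number from compound 2 to compound 3 (0.05 log units; within the scatter). Compound 3 is estimated at 10000 nM, with a range from 3000 nM to 33000 nM.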

Compound 3, half-maximal inhibitory concentration: > 20000 nM
Compound 3 was reported as a limit; the forecaster's own chance of this, stated with the estimate: 10%; middle value at least 2.0-fold (0.30 log units) away from the limit.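

Among these compounds, replacing the 4-(trifluoromethyl)phenyl group with 4-fluorophenyl is the first single-place change available, and in this assay it brings an at least 2.2-fold higher number from compound 2 to compound 3 (0.34 log units; beyond the scatter). This shows that the group on this aromatic carbon, para to a large group, matters to the reading on this core: the smaller fluoro gives the weaker result, by a margin beyond the scatter. The reading for compound 3 is a limit and not a number, so only the least size of the step can be stated: the limit of > 20000 nM in this assay, at which 1 of the 3 values shown sits.

The compounds shown leave open how other groups at this place would read on the same core, such as a methoxy, an amine or a carboxylic acid, and whether the order of trifluoromethyl and fluoro would hold there. They also leave open whether the same exchange would act alike on the core of compound 1, which carries a ketone and a sulfonate ester, and what the bromo of compound 1 contributes, since that compound differs from the others in more than one place.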